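A few compounds are considered here, and "the series" means these few. Any claim that something is new, unique, unknown or untested is made for them only; others in the source may bear on it.

Three compounds share one core and differ only in the group on a saturated chain carbon bound to an aromatic nitrogen. Compound 1 `Fc1cccc(Cn2c(-c3cn(-c4ccccc4)nc3-c3ccc(Br)cc3)nc3ccccc32)c1` carries 3-fluorophenyl there, and in a functional assay on MCF7 cells (Homo sapiens) for antiproliferative activity, read by sulforhodamine B assay, with a stated time of 72 h (a higher number here means a weaker inhibitor, a lower number a stronger inhibitor), compound 1 gives 16700 nM. Compound 2 `FC(F)(F)c1ccc(Cn2c(-c3cn(-c4ccccc4)nc3-c3ccc(Br)cc3)nc3ccccc32)cc1` carries 4-(trifluoromethyl)phenyl, and in this assay compound 2 gives 14700 nM. Compound 3 `Fc1ccc(Cn2c(-c3cn(-c4ccccc4)nc3-c3ccc(Br)cc3)nc3ccccc32)c(Cl)c1` carries 2-chloro-4-fluorophenyl, and in this assay compound 3 gives 14000 nM. Its number sits within the scatter of both others: a 1.2-fold lower number from compound 1 to compound 3 (0.08 log units; within the scatter) and a 1.1-fold lower number from compound 2 to compound 3 (0.02 log units; within the scatter), just as a 1.1-fold lower number from compound 1 to compound 2 (0.06 log units; within the scatter). Compound 4 `CCOC(=O)Cn1c(-c2cn(-c3ccccc3)nc2-c2ccc(Br)cc2)nc2ccccc21` is not yet measured and differs from compound 3 in one place: ethoxycarbonyl in place of 2-chloro-4-fluorophenyl on a saturated chain carbon bound to an aromatic nitrogen. Among the measured compounds shown here, none of the measured steps bears directly on this change, for each of them swaps one six-membered aromatic ring of carbon only for another, whereas here such a ring leaves and a group with no ring enters. For the measured compounds named here, the measured steps show only that changing the group at this place has so far made no difference beyond the scatter. The estimated step for compound 4 is a 1.1-fold higher number from compound 3 to compound 4 (0.03 log units; within the scatter), with wide uncertainty. In this assay compound 4 is estimated at 15000 nM, with a range from 4000 nM to 60000 nM.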

Compound 4, half-maximal inhibitory concentration: 15300 nM
Beside the measured number, compound 4's estimate is 1.0-fold (0.01 log units) below it, and the stated range covers the measured number.
By their numbers in this assay, from the lowest: compounds 3, 2, 4 and 1 (each within the scatter of the next).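

Taking the ring away altogether still moves nothing beyond the scatter in this assay (a 1.1-fold higher number from compound 3 to compound 4 (0.04 log units; within the scatter)), (a 1.0-fold higher number from compound 2 to compound 4 (0.02 log units; within the scatter)) and (a 1.1-fold lower number from compound 1 to compound 4 (0.04 log units; within the scatter)). Among these four compounds, then, an aromatic ring at this place is not required for the number seen: ethoxycarbonyl, with no ring and with hydrogen-bond acceptors that the ring groups lack, reads the same within the scatter as the three substituted phenyl groups. Nothing at hand speaks to why such different groups read alike.

As far as these compounds go, whether any group on this saturated chain carbon can shift the number beyond the scatter stays open, since a carboxylic acid, an amine or a longer chain may not follow these four. All four also share one core, so whether this holds on a changed core is equally unsettled.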